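Series notes: bicyclic-amide analogue, ortho-halogen phenyl swap

The source may hold more compounds than are shown below. What is called first, only, known or untested is meant among the compounds shown, and "the series" means these compounds.

Measured compounds:
- compound 1 `Fc1ccc(Nc2cc(Nc3ccc(Oc4ccncc4-c4cccnc4)c(F)c3)ncn2)cc1F`: 80 nM
- compound 2 `Fc1cc(Nc2cc(Nc3cccc(Cl)c3)ncn2)ccc1Oc1ccncc1-c1cccnc1`: 30 nM
- compound 3 `Cn1c(=O)c(C(=O)Nc2ccc(Oc3ccncc3-c3cccnc3)c(F)c2)nn(-c2ccccc2F)c1=O`: 4780 nM

Among the compounds with values here, in a functional assay on MKN-45 cells (Homo sapiens) for cytotoxicity, read by MTT assay, with a stated time of 72 h (on this read-out lower numbers stand for stronger inhibition and higher numbers for weaker inhibition), compound 3 gives 4780 nM, the highest number of the three; compound 1 gives 80 nM and compound 2 gives 30 nM, so compound 3 is the weakest compound measured so far in this assay, beyond the scatter in both comparisons.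

Compound 4 `Cn1c(=O)c(C(=O)Nc2ccc(Oc3ccncc3-c3cccnc3)c(F)c2)nn(-c2c(Cl)cccc2Cl)c1=O` differs from compound 3 in one place: 2,6-dichlorophenyl in place of 2-fluorophenyl on an aromatic nitrogen.

Within the data shown here, the only step measured is a 2.7-fold lower number from compound 1 to compound 2 (0.43 log units; beyond the scatter). That step changes an aryl group on an amine nitrogen of a different core and does not bear on the change from compound 3 to compound 4, which sits on an aromatic nitrogen of the amide-bearing core. Among the measured compounds shown here, no measured pair reports what adding a second halogen on the phenyl ring at this place does in this assay. With nothing directly comparable, the expectation for compound 4 is a small step at most, a 1.6-fold lower number from compound 3 to compound 4 (0.20 log units; within the scatter), with the direction uncertain.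

Compound 4 is therefore expected at about 3000 nM in this assay, within a range of 800 nM to 12000 nM.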

Compound 4, half-maximal inhibitory concentration: 3930 nM
Compound 4: the middle estimate sits 1.3-fold (0.12 log units) below what was measured; low and high end bracket the measured number.
By their numbers in this assay, from the lowest: compound 2; then compound 1; then compounds 4 and 3 (each within the scatter of the next).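

In this assay, 2,6-dichlorophenyl in place of 2-fluorophenyl on the aromatic nitrogen gives a 1.2-fold lower number from compound 3 to compound 4 (0.09 log units; within the scatter), so compound 3 and compound 4 cannot be told apart on this read-out. Within the data shown here, this is the first step read at this position: the earlier step concerned an aryl group on an amine nitrogen of the core of compound 1 and said nothing about this place, whereas this pair shows that exchanging one ortho-halogen phenyl for the dihalogenated one leaves the number within the usual scatter. Nothing measured on these compounds accounts for this outcome, so the pair records the size of the step and gives no reason for it.

The compounds shown cover only halogen-bearing phenyl groups on this nitrogen, so they leave open whether the same insensitivity would hold for a phenyl group carrying an amine or a carboxylic acid, or for a longer alkyl chain in place of the phenyl ring. They also leave open whether a change elsewhere on the shared core of compound 3 and compound 4 would move the number by more than the scatter.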